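Swapping a sulfur-containing ring for a dimethylimidazole

The source may report more compounds than this note shows. Statements on the series, on what has been measured and on what is new or still open speak of the compounds shown alone.

Compound 1 `CC(C)C(c1ccc(-c2ccc3cccc(F)c3c2)[nH]c1=O)N1CCCCS1(=O)=O` has the higher of the two numbers measured in a functional assay on CHO cells for antagonist activity at prostaglandin E2 receptor EP3 subtype (Homo sapiens), read by cAMP accumulation; on this read-out higher numbers stand for weaker inhibition and lower numbers for stronger inhibition: in this assay compound 1 gives 122 nM, while compound 2 `CCn1ncc2c(F)cc(-c3ccc(C(CC)(CC)c4nnc[nH]4)c(=O)[nH]3)cc21`, which differs from it in several places at once, gives 29 nM, a gap that lies beyond the usual scatter. Compound 3 `Cc1nc(C(c2ccc(-c3ccc4cccc(F)c4c3)[nH]c2=O)C(C)C)[nH]c1C` has not been measured yet. It differs from compound 1 in one place: a group of 7 heavy atoms (5 carbon, 2 nitrogen; one five-membered aromatic ring with 2 hetero atoms) in place of a group of 8 heavy atoms (4 carbon, 1 nitrogen, 2 oxygen, 1 sulfur; one six-membered non-aromatic ring with 2 hetero atoms), on a saturated chain carbon bound to an aromatic carbon and a saturated chain carbon. Going by the values given here, no measured pair shows this exact change, so the size of the step can only be guessed. Compound 2 also carries a small aromatic ring with two hetero atoms on the chain carbon next to its core and gives 29 nM, which hints that such a ring is tolerated there. Compound 3 is therefore expected to give 60 nM, within a range of 15 nM to 250 nM, and the expected step from compound 1 to compound 3 is a 2.0-fold lower number from compound 1 to compound 3 (0.31 log units; beyond the scatter), a modest gain that may still fall within the scatter.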

Compound 3, half-maximal inhibitory concentration: 50 nM
The estimate for compound 3 lay 1.2-fold (0.08 log units) above the measured number, within the range that was stated.
By their numbers in this assay, from the lowest: compounds 2 and 3 (each within the scatter of the next); then compound 1.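

Placing 4,5-dimethyl-1H-imidazol-2-yl on this saturated chain carbon, in place of the sulfur-containing six-membered ring, gives in this assay a 2.4-fold lower number from compound 1 to compound 3 (0.39 log units; beyond the scatter), a modest step. With the rest of the molecule unchanged, this shows that the six-membered non-aromatic ring is not required for activity at this position: a five-membered aromatic ring with a hydrogen-bond donor, which the departing group lacks, gives stronger inhibition. Nothing measured alongside these compounds gives a reason for the step.

A single swap cannot show which part of the new group matters, whether the ring itself, its hydrogen-bearing nitrogen or its methyl groups. A plain imidazole without the methyl groups, or an open-chain group such as dimethylamino on the same carbon, would help separate these possibilities.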